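The source may report more compounds than this note shows. Statements on the series, on what has been measured and on what is new or still open speak of the compounds shown alone.

Measured so far:
compound 1 `Cc1cc(=O)n(-c2ccccc2OC(F)(F)F)nc1C(=O)Nc1ccc(Oc2ncnc3ccsc23)cc1` — 23800 nM
compound 2 `Cc1cc(=O)n(-c2ccc(F)cc2)nc1C(=O)Nc1ccc(Oc2ncnc3ccsc23)cc1` — 4400 nM

Both were tested in a functional assay on MCF7 cells (Homo sapiens) for cytotoxicity, read by MTT assay, with a stated time of 72 h; a higher number here means a weaker inhibitor, a lower number a stronger inhibitor. Going by the values given here, compound 2 has the lowest of the two numbers; its nearest neighbour is compound 1, and the one measured step is a 5.4-fold lower number from compound 1 to compound 2 (0.73 log units; beyond the scatter), a change of the group carried on an aromatic nitrogen of the shared core. Compound 3 `Cc1cc(=O)n(-c2ccc(F)cc2)nc1C(=O)Nc1ccc(Oc2ncnc3ccsc23)c(F)c1` is derived from compound 2 by a change in a different part of the molecule: fluoro in place of hydrogen on an aromatic carbon. No measured pair differs at this ring, so the step of a 5.4-fold lower number from compound 1 to compound 2 (0.73 log units; beyond the scatter) does not bear on the new change, and nothing in the two numbers shown speaks for a shift in either direction. In the absence of a precedent, the expectation for compound 3 in this assay is a result close to that of compound 2, with a step within the usual scatter rather than beyond it. Compound 3 is therefore estimated at 4000 nM in this assay, with a range from 1300 nM to 12000 nM. This corresponds to an expected step of a 1.1-fold lower number from compound 2 to compound 3 (0.04 log units; within the scatter).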

Compound 3, half-maximal inhibitory concentration: 740 nM
Compound 3: middle estimate off by 5.4-fold (0.73 log units), on the high side; the whole stated range lies above it.
By their numbers in this assay, from the lowest: compound 3; then compound 2; then compound 1.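

Going by these compounds alone, until now, the only measured change was to the group on the aromatic nitrogen; here, in this assay, fluoro in place of hydrogen on an aromatic carbon, ortho to a large group and meta to a large group, gives a 5.9-fold lower number from compound 2 to compound 3 (0.77 log units; beyond the scatter). This shows that a second part of the molecule also affects the result, and that the entry of a single fluorine atom is enough to move the number beyond the usual scatter. No available measurement accounts for this shift.

The compounds shown leave open whether the gain is specific to fluoro, or whether another group on the same carbon, such as chloro, methyl or methoxy, would give a similar result, and whether fluoro elsewhere on that six-membered ring would do the same. As far as these compounds go, it is also open whether the step carries over to other groups on the aromatic nitrogen, such as the 2-(trifluoromethoxy)phenyl of compound 1, or holds only alongside the 4-fluorophenyl group.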